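Removing one methoxy from a thiazolidinedione benzimidazole pair

A few compounds are considered here, and "the series" means these few. Any claim that something is new, unique, unknown or untested is made for them only; others in the source may bear on it.

Of the compounds shown here, three have been measured in a functional assay on PC-3 cells (Homo sapiens) for inhibition, read by MTT assay, with a stated time of 48 h; a higher number here means a weaker inhibitor, a lower number a stronger inhibitor. Compound 1, `COc1cc(-c2nc3cc(/C=C4\SC(=O)NC4=O)ccc3[nH]2)cc(OC)c1OC`, gives 12000 nM in this assay. Compound 2, `COc1ccc(-c2nc3cc(/C=C4\SC(=O)NC4=O)ccc3[nH]2)cc1OC`, gives 8720 nM in this assay. Compound 3, `COc1cc(-c2nc3cc(/C=C4\SC(=O)N(CC(=O)N5CCOCC5)C4=O)ccc3[nH]2)cc(OC)c1OC`, gives 5940 nM in this assay; it carries the lowest of the three numbers, though its gap to compound 2 lies within the scatter.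

The change from compound 1 to compound 2 is hydrogen in place of methoxy on an aromatic carbon, and it made a 1.4-fold lower number from compound 1 to compound 2 (0.14 log units; within the scatter). The two cores differ by ((morpholin-4-yl)carbonyl)methyl in place of hydrogen on an amide-type nitrogen in a ring, a change that made a 2.0-fold lower number from compound 1 to compound 3 (0.31 log units; beyond the scatter).

Compound 4, `COc1ccc(-c2nc3cc(/C=C4\SC(=O)N(CC(=O)N5CCOCC5)C4=O)ccc3[nH]2)cc1OC`, is not yet measured. It differs from compound 3 by hydrogen in place of methoxy on an aromatic carbon, the same change as that from compound 1 to compound 2, made now on the core of compound 3. For the measured compounds named here, since that change made only a 1.4-fold lower number from compound 1 to compound 2 (0.14 log units; within the scatter), the expected step from compound 3 to compound 4 is a 1.4-fold lower number from compound 3 to compound 4 (0.14 log units; within the scatter), of the same small size, and rests on the single pair of compound 1 and compound 2. Compound 4 is therefore estimated to give 4300 nM in this assay, between 2000 nM and 9500 nM.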

Compound 4, half-maximal inhibitory concentration: > 50000 nM
Compound 4: only a limit was reported; the forecaster's own chance of this, stated with the estimate: 3%; at least 11-fold (1.06 log units) between middle value and limit.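

In this assay compound 4 gives > 50000 nM, which is a limit of the assay and not a number. Taking 3,4,5-trimethoxyphenyl to 3,4-dimethoxyphenyl now gave an at least 8.4-fold higher number from compound 3 to compound 4 (0.92 log units; beyond the scatter), and adding the ((morpholin-4-yl)carbonyl)methyl group gave an at least 5.7-fold higher number from compound 2 to compound 4 (0.75 log units; beyond the scatter), so neither change carried over from one core to the other: the same change on two cores in this assay, a 1.4-fold lower number (0.14 log units; within the scatter) from compound 1 to compound 2 and an at least 8.4-fold higher number (0.92 log units; beyond the scatter) from compound 3 to compound 4, at least 11-fold (1.06 log units) apart, beyond the scatter of two such steps This rests on four compounds only and shows that the two changes do not simply add in this pair; it does not show the full size of the loss, what lies behind it, or whether it would recur on another core.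

The compounds shown leave open whether the loss belongs to the morpholine amide itself or to any such chain on the amide-type nitrogen, which a piperidine amide, a dimethylamine amide or a free carboxylic acid there could separate. Also open, from the compounds shown here alone, is whether an ethoxy or a chlorine in place of the lost methoxy would restore the number of compound 3.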